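Bromo to hydroxy swap in an inactive triazole set

A few compounds are considered here, and "the series" means these few. Any claim that something is new, unique, unknown or untested is made for them only; others in the source may bear on it.

Measured compounds:
compound 1 `COc1ccc(-c2cn(-c3cc(OC)c(OC)c(OC)c3)nn2)cc1Br`: > 10000 nM
compound 2 `COc1ccc(-c2cn(-c3cc(OC)c(OC)c(OC)c3)nn2)cc1O`: > 10000 nM
compound 3 `COc1ccc(-c2cn(Cc3cc(OC)c(OC)c(OC)c3)nn2)cc1Br`: > 10000 nM

Of the compounds shown here, three have been tested in a functional assay on K562 cells (Homo sapiens) for cytotoxicity, read by MTT assay, with a stated time of 5 days; on this read-out lower numbers stand for stronger inhibition and higher numbers for weaker inhibition. Compound 1 `COc1ccc(-c2cn(-c3cc(OC)c(OC)c(OC)c3)nn2)cc1Br` gives only a limit of the assay, > 10000 nM. Compound 2 `COc1ccc(-c2cn(-c3cc(OC)c(OC)c(OC)c3)nn2)cc1O` likewise gives only a limit, > 10000 nM. The two differ by hydroxy in place of bromo on an aromatic carbon, and the step that the two limits leave unreadable from compound 1 to compound 2 cannot be read, because the limit of > 10000 nM in this assay, at which 3 of the 3 values shown sit, covers both. Compound 3 `COc1ccc(-c2cn(Cc3cc(OC)c(OC)c(OC)c3)nn2)cc1Br` also gives only a limit, > 10000 nM. The difference between the cores of compound 1 and compound 3 is not broken down here.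

Compound 4 `COc1ccc(-c2cn(Cc3cc(OC)c(OC)c(OC)c3)nn2)cc1O` has not yet been measured. It differs from compound 3 by hydroxy in place of bromo on an aromatic carbon, the same kind of change as that from compound 1 to compound 2; around compound 3 the change is additionally read one bond further out as 3-bromo-4-methoxyphenyl to 3-hydroxy-4-methoxyphenyl, a reading not given for compound 1. The step from compound 3 to compound 4 in this assay is expected to be a step that the limit leaves unreadable from compound 3 to compound 4, resting on compound 3 sitting at the limit, > 10000 nM, and on the same kind of change leaving compound 2 at its limit, > 10000 nM. Compound 4 is therefore estimated at 20000 nM, with a range from 8000 nM to 60000 nM, and most likely it will again be reported only as a limit.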

Compound 4, half-maximal inhibitory concentration: > 10000 nM
Compound 4 was reported as a limit (the forecaster's own chance of this, stated with the estimate: 85%); the middle value does not contradict the limit.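

In this assay compound 4 gives only a limit, > 10000 nM. The swap of bromo for hydroxy between compound 3 and compound 4 therefore yields no readable step, because both compounds sit at the same limit: the limit of > 10000 nM in this assay, at which 4 of the 4 values shown sit. The compounds shown leave open whether bromo and hydroxy differ at all in this cytotoxicity read-out, and which structure would give a true number instead of a limit.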